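This account rests on a few compounds, and the source may have more. Where it says the series, first, only, none or still open, it means among the compounds named here.

Three compounds built on one shared core differ only in the group carried on one phenyl ring. Compound 1 `Fc1ccc(C2=NN(C(=S)Nc3ccccc3)C(c3ccc4c(c3)OCCO4)C2)cc1` gives 37600 nM in a functional assay on HT-29 cells (Homo sapiens) for antiproliferative activity, read by MTT assay, with a stated time of 48 h (a higher number here means a weaker inhibitor of growth, a lower number a stronger inhibitor of growth), compound 2 `S=C(Nc1ccccc1)N1N=C(c2ccc(Br)cc2)CC1c1ccc2c(c1)OCCO2` gives 2580 nM, and compound 3 `FC(F)(F)c1ccc(C2=NN(C(=S)Nc3ccccc3)C(c3ccc4c(c3)OCCO4)C2)cc1` gives 97500 nM, the highest of the three numbers, which makes it the weakest growth inhibitor among them. The step of a 38-fold higher number from compound 2 to compound 3 (1.58 log units; beyond the scatter) was large, while the step of a 2.6-fold higher number from compound 1 to compound 3 (0.41 log units; beyond the scatter) was modest. Compound 4 `O=[N+]([O-])c1ccc(C2=NN(C(=S)Nc3ccccc3)C(c3ccc4c(c3)OCCO4)C2)cc1` carries nitro in place of trifluoromethyl on an aromatic carbon. Among the measured compounds shown here, no measured step exchanges this group, so the two known steps show only that changes at this position have shifted the numbers widely, in both directions. The expected step is a 3.9-fold lower number from compound 3 to compound 4 (0.59 log units; beyond the scatter). The estimate for compound 4 is therefore 25000 nM, with a range from 4000 nM to 150000 nM.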

Compound 4, concentration for 50% growth inhibition: 153000 nM
For compound 4 the middle estimate is 6.1-fold (0.79 log units) below the measured one; measured number above the stated range.
By their numbers in this assay, from the lowest: compound 2; then compound 1; then compounds 3 and 4 (each within the scatter of the next).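

In this assay, putting nitro in place of trifluoromethyl gives a 1.6-fold higher number from compound 3 to compound 4 (0.20 log units; within the scatter), so this exchange leaves the two groups indistinguishable here. Nitro stands far from bromo, with a 59-fold higher number from compound 2 to compound 4 (1.77 log units; beyond the scatter), and more modestly from fluoro, with a 4.1-fold higher number from compound 1 to compound 4 (0.61 log units; beyond the scatter), so bromo still gives the lowest number of the four. Nothing measured here explains why these groups differ as they do. As far as these compounds go, whether that low number is special to bromo stays open. Chloro, iodo, an amine or a methoxy group on the same carbon could show how far it extends.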